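A few compounds are considered here, and "the series" means these few. Any claim that something is new, unique, unknown or untested is made for them only; others in the source may bear on it.

In an ADME assay on L6 cells (Rattus norvegicus) for cytotoxicity (on this read-out higher numbers stand for weaker inhibition and lower numbers for stronger inhibition), three compounds have been measured:
compound 1 `CCN(CC)CC(=O)OC1CC2(N3CCCC3)CC(c3ccccc3)C1C(c1ccccc1)C2` gives 49000 nM;
compound 2 `O=C(CN1CCCC1)OC1CC2(N3CCCC3)CC(c3ccccc3)C1C(c1ccccc1)C2` gives 42900 nM;
compound 3 `CCN(CC)CCC(=O)OC1CC2(N(C)C)CC(c3ccccc3)C1C(c1ccccc1)C2` gives 23600 nM.

Compound 2 differs from compound 1 by pyrrolidin-1-yl in place of diethylamino on a saturated chain carbon bound to a carbonyl carbon, and this change gave a 1.1-fold lower number from compound 1 to compound 2 (0.06 log units; within the scatter). Compound 4 `CN(C)C12CC(OC(=O)CCN3CCCC3)C(C(c3ccccc3)C1)C(c1ccccc1)C2` has not been measured yet; it differs from compound 3 by pyrrolidin-1-yl in place of diethylamino on a saturated chain carbon, two bonds along the chain from a carbonyl carbon. Going by the values given here, this is the same kind of change as the one from compound 1 to compound 2, but not the same: there the new group sits on a saturated chain carbon bound to a carbonyl carbon, here on a saturated chain carbon, two bonds along the chain from a carbonyl carbon. The difference between the core of compound 1 and the core of compound 3 is not broken down here. Because a 1.1-fold lower number from compound 1 to compound 2 (0.06 log units; within the scatter) stayed within the scatter, a similarly small step is expected here, a 1.1-fold lower number from compound 3 to compound 4 (0.03 log units; within the scatter). Compound 4 is therefore estimated at 22000 nM in this assay, most likely between 11000 nM and 45000 nM.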

Compound 4, half-maximal inhibitory concentration: 26000 nM
The estimate for compound 4 lay 1.2-fold (0.07 log units) below the measured number; the measured number falls inside the stated range.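

In this assay, pyrrolidin-1-yl in place of diethylamino gave a 1.1-fold higher number from compound 3 to compound 4 (0.04 log units; within the scatter), and the same kind of swap on the two cores gave steps that do not differ: the same change on two cores in this assay, a 1.1-fold lower number (0.06 log units; within the scatter) from compound 1 to compound 2 and a 1.1-fold higher number (0.04 log units; within the scatter) from compound 3 to compound 4, 1.3-fold (0.10 log units) apart, within the scatter of two such steps

In these two pairs, then, the swap carried from one core to the other without moving the number beyond the usual scatter. This does not show that it would carry over to other cores, and since both steps are small, it cannot show how a change with a large effect would transfer.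

From the compounds shown here alone, it remains open whether a larger ring such as piperidine, or a ring with a second hetero atom such as morpholine, would behave the same way in this place. A carboxylic acid in place of the amine is also left open.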